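From a cyclohexyl to a trifluoromethylphenyl amine

The source may report more compounds than this note shows. Statements on the series, on what has been measured and on what is new or still open speak of the compounds shown alone.

Three compounds share a core and differ only in the group on the amine nitrogen. In a functional assay on MGC-803 cells (Homo sapiens) for inhibition, read by sulforhodamine B assay (a lower number here means a stronger inhibitor, a higher number a weaker inhibitor), compound 1 `Cc1ccc(NC2=CC(=O)c3c(nc4n3[C@H]3OC[C@@H](O)[C@H]3OC4)C2=O)cc1C` gives 1050 nM, and compound 2 `CCOc1ccc(NC2=CC(=O)c3c(nc4n3[C@H]3OC[C@@H](O)[C@H]3OC4)C2=O)cc1` gives 2090 nM; the step of a 2.0-fold higher number from compound 1 to compound 2 (0.30 log units; within the scatter) is within the scatter. Compound 3 `O=C1C(NC2CCCCC2)=CC(=O)c2c1nc1n2[C@H]2OC[C@@H](O)[C@H]2OC1` gives > 8000 nM, which is a limit of the assay rather than a number, so compound 3 stands at the weak end of what has been measured. The two steps into compound 3, an at least 7.6-fold higher number from compound 1 to compound 3 (0.88 log units; beyond the scatter) and an at least 3.8-fold higher number from compound 2 to compound 3 (0.58 log units; beyond the scatter), both show that a cyclohexyl on the amine nitrogen gives a weaker inhibitor than an aromatic ring there.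

Compound 4 `O=C1C(Nc2ccc(C(F)(F)F)cc2)=CC(=O)c2c1nc1n2[C@H]2OC[C@@H](O)[C@H]2OC1` reverses that kind of change: 4-(trifluoromethyl)phenyl in place of cyclohexyl on an amine nitrogen. Since both aryl compounds gave numbers well below the limit at which compound 3 sits, a step back toward those numbers is expected, that is a clear drop in an at least 4.0-fold lower number from compound 3 to compound 4 (0.60 log units; beyond the scatter). Compound 4 is therefore estimated at 2000 nM, with a likely range from 700 nM to 6000 nM.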

Compound 4, half-maximal inhibitory concentration: 1860 nM
Compound 4: the middle estimate sits 1.1-fold (0.03 log units) above what was measured; the range from low to high includes it.
By their numbers in this assay, from the lowest: compounds 1, 4 and 2 (each within the scatter of the next). At a limit, above all of these: compound 3.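

In this assay a third aromatic ring on the amine nitrogen, 4-(trifluoromethyl)phenyl, also gives a stronger inhibitor than cyclohexyl (an at least 4.3-fold lower number from compound 3 to compound 4 (0.63 log units; beyond the scatter)), so the aryl compounds shown now rest on three different rings. Changing what the ring carries has no readable effect so far: trifluoromethyl in place of ethoxy (a 1.1-fold lower number from compound 2 to compound 4 (0.05 log units; within the scatter)) and 4-(trifluoromethyl)phenyl in place of 3,4-dimethylphenyl (a 1.8-fold higher number from compound 1 to compound 4 (0.25 log units; within the scatter)) both stay within the scatter. The full size of the gap to cyclohexyl remains unknown because compound 3 sits at a limit of the assay: the limit of > 8000 nM in this assay, at which 1 of the 4 values shown sits.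

Still open, on these data alone, is whether a plain phenyl, or a phenyl carrying an amine or a carboxylic acid, would behave like these three rings. Also open, as far as these compounds go, is how a pyridine ring or a short open chain such as ethyl would fare on the same nitrogen.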